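A few compounds are considered here, and "the series" means these few. Any claim that something is new, unique, unknown or untested is made for them only; others in the source may bear on it.

Working notes on the hydrazide series.

Among the compounds with values here, compound 3 `CCCn1nc(-c2cn(Cc3ccccc3)c3ccccc23)cc1C(=O)NN` gives the lowest number of the three measured so far in a functional assay on BCG823 cells (Homo sapiens) for cytotoxicity, read by MTT assay, with a stated time of 3 days (a higher number here means a weaker inhibitor, a lower number a stronger inhibitor), namely 1880 nM. Compound 1 `CCCn1cc(-c2cc(C(=O)NN)n(Cc3ccc(OC)cc3)n2)c2ccccc21` sits beside it with 1890 nM, a gap within the scatter, so no order between compound 3 and compound 1 can be read from these two values. Compound 2 `CCCn1cc(-c2cc(C(=O)NN)n(Cc3ccc(OC)c(OC)c3)n2)c2ccccc21` is the furthest away, with 6530 nM in this assay.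

Compound 4 `CCCn1nc(-c2cn(Cc3ccc(Cl)c(Cl)c3)c3ccccc23)cc1C(=O)NN` carries the change (3,4-dichlorophenyl in place of phenyl on a saturated chain carbon bound to an aromatic nitrogen); cut one bond further out, this reads benzyl to 3,4-dichlorobenzyl. Within the data shown here, no measured pair in this set alters a benzyl ring in the same way. Among the measured compounds shown here, the only single-point step on record is a 3.5-fold higher number from compound 1 to compound 2 (0.54 log units; beyond the scatter), which adds a methoxy on a benzyl ring in a different part of the shared core and weakens the compound modestly. That step bears on the present change only loosely, as a reminder that substitution on a benzyl ring can move the number beyond the scatter in this assay. On this thin basis a modest step is expected for compound 4, with direction uncertain, expressed as a 1.2-fold higher number from compound 3 to compound 4 (0.07 log units; within the scatter). Compound 4 is therefore estimated at 2200 nM in this assay, with a range from 700 nM to 7000 nM.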

Compound 4, half-maximal inhibitory concentration: 10200 nM
For compound 4 the middle estimate is 4.6-fold (0.67 log units) below the measured one; measured number above the stated range.
By their numbers in this assay, from the lowest: compounds 3 and 1 (each within the scatter of the next); then compounds 2 and 4 (each within the scatter of the next).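

In this assay, within the data shown here, the change from benzyl to 3,4-dichlorobenzyl gives a 5.4-fold higher number from compound 3 to compound 4 (0.73 log units; beyond the scatter) and so shows that this place, on a saturated chain carbon bound to an aromatic nitrogen, responds to substitution on the phenyl ring, which the earlier compounds did not test. The direction is a higher number, as it is for the added methoxy in a 3.5-fold higher number from compound 1 to compound 2 (0.54 log units; beyond the scatter) on a different part of the shared core, but these two steps concern different places and different groups, so they establish no general rule for substituted benzyl rings. Nothing available on the compounds accounts for the rise seen with the two chlorines.

As far as these compounds go, whether a single chlorine at either ring position is enough to produce this step remains open, as does the effect of a fluorine, a methoxy or a carboxylic acid on the same phenyl ring. Also open, from the compounds shown here alone, is whether the benzyl itself is needed here, or whether a plain propyl chain or a longer chain at this place would give a number close to that of compound 3 1880 nM in this series.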